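This account rests on a few compounds, and the source may have more. Where it says the series, first, only, none or still open, it means among the compounds named here.

In an ADME assay on RAW264.7 cells (Mus musculus) for cytotoxicity, read by MTT assay, with a stated time of 48 h (on this read-out lower numbers stand for stronger inhibition and higher numbers for weaker inhibition), compound 1 (`N#Cc1ccc(C(=O)Nc2ccc(NS(=O)(=O)C(F)(F)F)c(Cl)c2)cc1`) gives only a limit, > 250000 nM, so no number is known for it there. Within the data shown here, compound 2 (`CCS(=O)(=O)Nc1ccc(NC(=O)c2ccc(C#N)cc2)cc1F`) is the one compound with a measured number in this assay, where it gives 107000 nM; of the two values shown, it is the only one that is a number rather than a limit.

Compound 3 (`N#Cc1ccc(C(=O)Nc2ccc(NS(=O)(=O)C(F)(F)F)c(F)c2)cc1`) has not yet been measured in this assay. It differs from compound 2 in one place: trifluoromethyl in place of ethyl on a sulfonyl sulfur. Compound 1 carries the same ((trifluoromethyl)sulfonyl)amino group, and in this assay it sits at the limit, as the record the limit of > 250000 nM in this assay, at which 1 of the 2 values shown sits, shows.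

Among the measured compounds shown here, no step between two measured compounds is available to size this change. Given that compound 1 sits at the limit and compound 2 gives a weak number, compound 3 is expected to show weak cytotoxicity as well, with a step from compound 2 to compound 3 of a 1.7-fold higher number from compound 2 to compound 3 (0.23 log units; within the scatter) toward a higher number, possibly reaching the limit. The estimate for compound 3 in this assay is 180000 nM, within a range of 80000 nM to 320000 nM.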

Compound 3, half-maximal inhibitory concentration: > 250000 nM
Compound 3: a limit, no number (the forecaster's own chance of this, stated with the estimate: 40%); middle value at least 1.3-fold (0.14 log units) away from the limit.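

Replacing ethyl with trifluoromethyl on a sulfonyl sulfur whose other neighbour is the sulfonamide nitrogen gives an at least 2.3-fold higher number from compound 2 to compound 3 (0.36 log units; beyond the scatter) in this assay, so this single change now has a lower bound on its size. Compound 1 also carries the ((trifluoromethyl)sulfonyl)amino group, but it differs from compound 2 in more than one place, so it could not isolate this change as compound 3 does. From the compounds shown here alone, the step with fluoro in place of chloro on an aromatic carbon cannot be read, and the full size of the step to trifluoromethyl also remains unknown, as the result reaches the end of the measurable range: the limit of > 250000 nM in this assay, at which 2 of the 3 values shown sit.

Going by these compounds, it remains open how far the number would rise if the assay could measure beyond its limit, and whether a longer chain such as propyl on the sulfonyl sulfur would give a number or a limit. On these data alone, it is also open whether an amine or a carboxylic acid in place of the nitrile would shift the read-out on this core.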